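The source may report more compounds than this note shows. Statements on the series, on what has been measured and on what is new or still open speak of the compounds shown alone.

Three compounds share one core and differ only in the group on the phenyl attached to the nitrogen: compound 1 `Cc1ccc(S(=O)(=O)N(Cc2nc3ccccc3[nH]2)c2ccccc2)cc1`, compound 2 `Cc1ccc(N(Cc2nc3ccccc3[nH]2)S(=O)(=O)c2ccc(C)cc2)cc1` and compound 3 `COc1ccc(N(Cc2nc3ccccc3[nH]2)S(=O)(=O)c2ccc(C)cc2)cc1`. In a functional assay on PC-3 cells (Homo sapiens) for inhibition, read by MTT assay, with a stated time of 48 h (on this read-out lower numbers stand for stronger inhibition and higher numbers for weaker inhibition), compound 1 reaches only a limit of the assay and gives > 50000 nM. Compound 2 gives 48900 nM in this assay. Compound 3 again stands at a limit of this assay and gives > 50000 nM. The measured steps are accordingly small or unreadable: an at least 1.0-fold lower number from compound 1 to compound 2 (0.00 log units; that floor lies within the scatter), an at least 1.0-fold higher number from compound 2 to compound 3 (0.00 log units; that floor lies within the scatter), and a step that the two limits leave unreadable from compound 1 to compound 3. Two of the three values rest on (the limit of > 50000 nM in this assay, at which 2 of the 3 values shown sit), so compound 3 stands at the weak end of what this assay can report.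

Compound 4 `COc1ccc(N(Cc2nc3ccccc3[nH]2)S(=O)(=O)c2ccc(C)cc2)cc1OC` has not yet been measured. It differs from compound 3 in one place: methoxy in place of hydrogen on an aromatic carbon. Among the compounds with values here, the steps that bear on this change are the methyl and methoxy additions to compound 1 and the swap between them, all of which left the numbers at or near the limit. A second methoxy is therefore expected to change little, and the expected step is a number no higher from compound 3 to compound 4 (the limit leaves the size open). Compound 4 is estimated at 50000 nM, within a range from 20000 nM to 120000 nM, and most likely this assay will again report only a limit.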

Compound 4, half-maximal inhibitory concentration: > 50000 nM
Compound 4 was reported as a limit; the forecaster's own chance of this, stated with the estimate: 65%; the middle value sits exactly at the limit.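

Placing a second methoxy on the 4-methoxyphenyl of compound 3, ortho to the first, gives the 3,4-dimethoxyphenyl group of compound 4, and this change does not bring a readable number in this assay. Within the data shown here, compound 4 is reported only as a limit, so the steps that link it to compound 3 and to compound 1 cannot be read, and the one step with a stated floor is an at least 1.0-fold higher number from compound 2 to compound 4 (0.00 log units; that floor lies within the scatter). Among these compounds, what this adds to the earlier compounds is that a ring carrying two methoxy groups also gives no number that can be placed on the scale, and the set now gathers at one end of what the assay can report: the limit of > 50000 nM in this assay, at which 3 of the 4 values shown sit.

On these data alone, the true values of compound 3 and compound 4 remain unknown, so the data cannot tell whether the second methoxy strengthens inhibition, weakens it or leaves it unchanged. As far as these compounds go, it also remains open whether an amine or a carboxylic acid on this same ring would give a number that can be read in this assay.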